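The source may hold more compounds than are shown below. What is called first, only, known or untested is meant among the compounds shown, and "the series" means these compounds.

Compound 1, `C#CCNC1CCc2c(OCCCN3CCN(c4cccc5c4ccn5Cc4cccc(Cl)c4)CC3)cccc21` — > 1000 nM
Compound 2, `C#CCNC1CCc2c(OCCCCCN3CCN(c4cccc5c4ccn5Cc4cccc(Cl)c4)CC3)cccc21` — 460 nM
Compound 3, `C[C@H](NCc1ccc(OCCCCCCN2CCN(c3cccc4c3ccn4Cc3cccc(Cl)c3)CC2)cc1)C(N)=O` — > 1000 nM

Of the compounds shown here, three have been measured in an assay on BTI cells for inhibition of Amine oxidase [flavin-containing] B (Homo sapiens), read by fluorescence, with stated times of 30 min and 1 h; on this read-out higher numbers stand for weaker inhibition and lower numbers for stronger inhibition. For compound 1 the result is a limit of the assay, > 1000 nM, not a number. Compound 2 gives a numerical value, 460 nM. For compound 3 the result is again a limit, > 1000 nM, and it therefore stands, together with compound 1, at the limit of > 1000 nM in this assay, at which 2 of the 3 values shown sit; no number places it relative to compound 2.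

The next compound, compound 4, `C#CCN(C)Cc1ccc(OCCCCCCN2CCN(c3cccc4c3ccn4Cc3cccc(Cl)c3)CC2)cc1`, differs from compound 3 in one place: methyl(propargyl)amino in place of (1-carbamoylethyl)amino on a saturated chain carbon bound to an aromatic carbon. Because compound 2, which carries a propargyl group on its amine, gives 460 nM, compound 4 is expected to give a measurable value. The step from compound 3 to compound 4 is estimated at an at least 2.5-fold lower number from compound 3 to compound 4 (0.39 log units; beyond the scatter) in this assay, towards stronger inhibition, beyond the usual scatter. For compound 4 the estimated value in this assay is 400 nM, with a range from 100 nM to 2000 nM.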

Compound 4, half-maximal inhibitory concentration: > 1000 nM
Compound 4 ended at the assay's limit; the forecaster's own chance of this, stated with the estimate: 25%; at least 2.5-fold (0.39 log units) between middle value and limit.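

In this assay compound 4 gives > 1000 nM, a limit of the assay and not a number. Compound 3 also sits at a limit, so no step between compound 3 and compound 4 can be read: the limit of > 1000 nM in this assay, at which 3 of the 4 values shown sit.

The compounds shown leave open whether methyl(propargyl)amino in place of (1-carbamoylethyl)amino changes inhibition at all.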